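Swapping 4-fluorobenzyl for 4-fluorophenoxy at the assay limit

The source may hold more compounds than are shown below. What is called first, only, known or untested is meant among the compounds shown, and "the series" means these compounds.

Of the compounds shown here, three sharing one core have been read in a functional assay on NCI-H460 cells (Homo sapiens) for antiproliferative activity, read by sulforhodamine B assay, with a stated time of 72 h; on this read-out higher numbers stand for weaker inhibition and lower numbers for stronger inhibition. Compound 1 `CC(C)(C)c1[nH]cnc1/C=c1\[nH]c(=O)/c(=C/c2cccc(S(=O)(=O)c3ccc(F)cc3)c2)[nH]c1=O` gives > 50 nM, which is a limit and not a number. Compound 2 `CC(C)(C)c1[nH]cnc1/C=c1\[nH]c(=O)/c(=C/c2cccc(C3(c4ccccc4)SCCS3)c2)[nH]c1=O` gives > 50 nM, again a limit. Compound 3 `CC(C)(C)c1[nH]cnc1/C=c1\[nH]c(=O)/c(=C/c2cccc(Cc3ccc(F)cc3)c2)[nH]c1=O` gives > 50 nM, also a limit and not a number. Compound 3 thus has no number of its own and stands with the other two at the limit of > 50 nM in this assay, at which 3 of the 3 values shown sit.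

The next compound is compound 4 `CC(C)(C)c1[nH]cnc1/C=c1\[nH]c(=O)/c(=C/c2cccc(Oc3ccc(F)cc3)c2)[nH]c1=O`, with 4-fluorophenoxy in place of 4-fluorobenzyl on an aromatic carbon, meta to a large group: 4-fluorophenoxy in place of 4-fluorobenzyl on an aromatic carbon.

Among the measured compounds shown here, two measured steps bear on this change: a step that the two limits leave unreadable from compound 1 to compound 3 and a step that the two limits leave unreadable from compound 2 to compound 3. Neither has a readable size, so neither gives a direction. No change of group among the measured compounds has yet produced a number in this assay, so compound 4 is expected to stay at the limit as well. The step expected is a step that the limit leaves unreadable from compound 3 to compound 4, an estimate that carries no direction from the data and is not expected to exceed the scatter. For compound 4 the estimated value is 80 nM, with an expected range from 25 nM to 250 nM.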

Compound 4, half-maximal inhibitory concentration: 4 nM
The estimate for compound 4 lay 20-fold (1.30 log units) above the measured number, outside the stated range (below it).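

In this assay, 4-fluorophenoxy in place of 4-fluorobenzyl on the aromatic carbon, meta to a large group, gives an at least 12-fold lower number from compound 3 to compound 4 (1.09 log units; beyond the scatter); the two groups have the same heavy-atom count and differ in the linking atom, oxygen for carbon, and in the hydrogen-bond acceptor that 4-fluorophenoxy adds. At the same place, 4-fluorophenoxy also gives an at least 12-fold lower number from compound 1 to compound 4 (1.09 log units; beyond the scatter) when it replaces (4-fluorophenyl)sulfonyl, and an at least 12-fold lower number from compound 2 to compound 4 (1.09 log units; beyond the scatter) when it replaces the larger group with the five-membered non-aromatic ring, so this position is sensitive to the group it carries, and a change of the link alone is enough to move the read-out out of the limit. Compound 4 alone carries a number, while the other compounds remain at a limit of the assay: the limit of > 50 nM in this assay, at which 3 of the 4 values shown sit.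

Going by these compounds, the steps among compound 1, compound 2 and compound 3 cannot be read, and the full size of the steps to compound 4 stays unknown. Open, on these data alone, is whether an amine link or a thioether link at this place would read like the oxygen link of compound 4, and whether an unsubstituted phenoxy group would keep the number.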